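The compounds below may be only part of what the source reports. "The series", "measured", "known", "first", "only" and "open" are said of these compounds alone.

Across the compounds shown, one core is kept and only the aromatic group on the carbon with a double bond to nitrogen changes. Compound 1 `CC1=CC[C@H](C(C)(C)NC(=S)N/N=C/c2ccc(N(C)C)cc2)CC1` carries dimethylamino on that ring, and in a functional assay on 786-0 cells (Homo sapiens) for inhibition, read by sulforhodamine B assay, with a stated time of 48 h (a higher number here means a weaker inhibitor of growth, a lower number a stronger inhibitor of growth), compound 1 gives 87000 nM. Compound 3 `COc1cc(/C=N/NC(=S)NC(C)(C)[C@H]2CC=C(C)CC2)ccc1O` carries methoxy and hydroxy groups instead, and in this assay compound 3 gives 12900 nM. Compound 2 `CC1=CC[C@H](C(C)(C)NC(=S)N/N=C/c2ccc(F)cc2)CC1` carries fluoro in place of dimethylamino. In this assay compound 2 reaches only a limit, > 100000 nM, namely (the limit of > 100000 nM in this assay, at which 1 of the 3 values shown sits). Because of the limit of > 100000 nM in this assay, at which 1 of the 3 values shown sits, the step of an at least 1.1-fold higher number from compound 1 to compound 2 (0.06 log units; that floor lies within the scatter) can be given only as a floor. Compound 2 thus sits at the weak end of the numbers shown, at the limit itself, with compound 1 close by and compound 3 the only one clearly away from it.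

Compound 4 `CC1=CC[C@H](C(C)(C)NC(=S)N/N=C/c2cccs2)CC1` differs from compound 2 in one place: thiophen-2-yl in place of 4-fluorophenyl on a carbon with a double bond to nitrogen. Going by the values given here, no measured step replaces the aromatic ring; the single measured step, an at least 1.1-fold higher number from compound 1 to compound 2 (0.06 log units; that floor lies within the scatter), only swaps one substituent on that ring and stays within the scatter. With nothing pointing to a gain, compound 4 is expected to show no step beyond the scatter, an at least 1.1-fold lower number from compound 2 to compound 4 (0.04 log units; that floor lies within the scatter). Compound 4 is therefore estimated at 90000 nM, with a range from 30000 nM to 200000 nM.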

Compound 4, concentration for 50% growth inhibition: 11500 nM
The estimate for compound 4 lay 7.8-fold (0.89 log units) above the measured number, and the stated range ends above it.
By their numbers in this assay, from the lowest: compounds 4 and 3 (each within the scatter of the next); then compound 1. At a limit, above all of these: compound 2.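

Replacing the aromatic ring itself, rather than a substituent on it, moves the number well beyond the scatter in this assay: thiophen-2-yl in place of 4-fluorophenyl on a carbon with a double bond to nitrogen gives an at least 8.6-fold lower number from compound 2 to compound 4 (0.93 log units; beyond the scatter). The values of compound 3 and compound 4 lie within the scatter of each other, so in this small set a hydroxy group on the aromatic ring is not required to reach that range of numbers. Going by these compounds, the true size of the step remains unknown, and it can be given only as a floor because compound 2 stands at a limit: the limit of > 100000 nM in this assay, at which 1 of the 4 values shown sits.

On these data alone, it remains open whether the change depends on the sulfur atom, on the five-membered ring, or on the absence of the fluoro group, and a furan-2-yl, pyridin-2-yl or plain phenyl group at the same place would help separate these possibilities. Also open, as far as these compounds go, is whether a methyl group or a chloro group on the thiophen-2-yl ring would shift the number further.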